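A Smaller Group on the Ring Nitrogen, Tested Twice

The compounds below may be only part of what the source reports. "The series", "measured", "known", "first", "only" and "open" are said of these compounds alone.

Four compounds share a fused two-ring core carrying a sulfonamide-bearing aromatic arm, and they were examined in a functional assay on A549 cells (Homo sapiens) for antiproliferative activity, read by MTT assay, with a stated time of 72 h; a lower number here means a stronger inhibitor, a higher number a weaker inhibitor. Compound 1 `COc1cccc(N2C(=O)COc3ccc(-c4cnc(Cl)c(NS(=O)(=O)c5ccc(F)cc5)c4)cc32)c1` carries a 3-methoxyphenyl on the amide-type nitrogen of the core, and in this assay compound 1 gives 32700 nM. Compound 2 `CC(C)N1C(=O)COc2ccc(-c3cnc(Cl)c(NS(=O)(=O)c4ccc(F)cc4)c3)cc21` differs from it by the change (isopropyl in place of 3-methoxyphenyl on an amide-type nitrogen in a ring), and in this assay compound 2 gives 5100 nM. That single swap produced a 6.4-fold lower number from compound 1 to compound 2 (0.81 log units; beyond the scatter).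

Compound 3 `COc1cccc(N2C(=O)COc3ccc(-c4cccc(NS(=O)(=O)c5ccc(F)cc5)c4)cc32)c1` keeps the 3-methoxyphenyl of compound 1 but has a different aromatic arm; the difference between the two cores is not broken down here. In this assay compound 3 gives > 40000 nM, which is a limit of the assay rather than a number, consistent with the limit of > 40000 nM in this assay, at which 1 of the 3 values shown sits.

Compound 4 `CC(C)N1C(=O)COc2ccc(-c3cccc(NS(=O)(=O)c4ccc(F)cc4)c3)cc21` is compound 3 after the change (isopropyl in place of 3-methoxyphenyl on an amide-type nitrogen in a ring), the same change that turned compound 1 into compound 2, made at the same place. If compound 4 follows the pattern seen between compound 1 and compound 2, a step of similar size is expected; since the starting point of compound 3 is only a limit, the estimated landing point is uncertain, and compound 4 may itself sit at the limit. The expected step is an at least 2.6-fold lower number from compound 3 to compound 4 (0.42 log units; beyond the scatter), and in this assay compound 4 is estimated at 15000 nM, most likely between 5000 nM and 40000 nM.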

Compound 4, half-maximal inhibitory concentration: 29400 nM
The estimate for compound 4 lay 2.0-fold (0.29 log units) below the measured number; the range from low to high includes it.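

In this assay, isopropyl in place of 3-methoxyphenyl on the amide-type nitrogen was tried on a second core, and the new step is an at least 1.3-fold lower number from compound 3 to compound 4 (0.13 log units; that floor lies within the scatter), so a lower number is allowed here, but the printed floor alone does not establish a change beyond the scatter. For compound 3, the reading of > 40000 nM is a limit of the assay and not a number. The second pair therefore does not contradict the first, but it also does not show that the change carries over from one core to the other at the same size, or at a smaller one: the same change on two cores in this assay, a 6.4-fold lower number (0.81 log units; beyond the scatter) from compound 1 to compound 2 and an at least 1.3-fold lower number (0.13 log units; that floor lies within the scatter) from compound 3 to compound 4; the limit leaves it open whether they differ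

The compounds shown leave open how other groups on the amide-type nitrogen would read in this series, such as a longer chain like n-butyl, or a chain ending in an amine or a carboxylic acid. They also leave open how the difference between the two aromatic arms, which is not broken down here, bears on the size of the step, and two pairs of compounds are too few to settle a rule for the series.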